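Oxidizing the Sulfur: Thioether to Sulfone on the Chain

The compounds below may be only part of what the source reports. "The series", "measured", "known", "first", "only" and "open" are said of these compounds alone.

Compound 1 `CCOCCON1C(=O)[C@@H](NC(=O)OCCCCC2CCCCC2)[C@@H]1C` and compound 2 `CSCCCON1C(=O)[C@@H](NC(=O)OCCCCC2CCCCC2)[C@@H]1C` share one core and differ only in the chain on the ring nitrogen. In an assay on HEK293 cells for inhibition of N-acylethanolamine-hydrolyzing acid amidase (Homo sapiens), read by fluorescence, with stated times of 10 min and 50 min (a higher number here means a weaker inhibitor, a lower number a stronger inhibitor), compound 1 gives 187 nM and compound 2 gives 167 nM; the step of a 1.1-fold lower number from compound 1 to compound 2 (0.05 log units; within the scatter) leaves the two level, so compound 2 stands beside compound 1 rather than ahead of it. Compound 3 `C[C@H]1[C@H](NC(=O)OCCCCC2CCCCC2)C(=O)N1OCCCS(C)(=O)=O` is not yet measured; it differs from compound 2 by methylsulfonyl in place of methylsulfanyl on a saturated chain carbon, three bonds along the chain from an oxygen on an unsaturated carbon. Within the data shown here, no measured step touches the sulfur itself, and the one step in hand, a 1.1-fold lower number from compound 1 to compound 2 (0.05 log units; within the scatter), was small, so no change beyond the scatter is expected. Compound 3 is therefore estimated at 200 nM, between 70 nM and 600 nM, which would mean a 1.2-fold higher number from compound 2 to compound 3 (0.08 log units; within the scatter).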

Compound 3, half-maximal inhibitory concentration: 49 nM
The estimate for compound 3 lay 4.1-fold (0.61 log units) above the measured number; the measured number lies below the stated range.
By their numbers in this assay, from the lowest: compound 3; then compounds 2 and 1 (each within the scatter of the next).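

In this assay this chain position responds to a change at the sulfur: methylsulfonyl in place of methylsulfanyl gives a 3.4-fold lower number from compound 2 to compound 3 (0.53 log units; beyond the scatter) and so goes beyond the scatter, which the step from ethoxy to (methylsulfanyl)methyl did not. Against the ethoxy chain, the methylsulfonyl chain gives a 3.8-fold lower number from compound 1 to compound 3 (0.58 log units; beyond the scatter) as well, so it stands apart from both earlier chains. Nothing in the data at hand accounts for this step. From the compounds shown here alone, whether a sulfonamide or a carboxylic acid in place of methylsulfonyl would match this result stays open. So does whether a longer chain than 3-(methylsulfonyl)propyl would keep it.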